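The source may report more compounds than this note shows. Statements on the series, on what has been measured and on what is new or still open speak of the compounds shown alone.

Measured compounds:
- compound 1 `Cc1ccc(-c2cc(NC(=O)/C=C/c3ccc(C(F)(F)F)cc3)n[nH]2)cc1`: 1020 nM
- compound 2 `O=C(/C=C/c1ccc(Br)cc1)Nc1cc(-c2ccc(Br)cc2)[nH]n1`: 1360 nM
- compound 3 `COc1ccc(/C=C/C(=O)Nc2cc(-c3ccc(Br)cc3)[nH]n2)cc1`: 820 nM

Three compounds of the series have been run in a functional assay on A549 cells (Homo sapiens) for antiproliferative activity, read by MTT assay, with a stated time of 48 h; a lower number here means a stronger inhibitor, a higher number a weaker inhibitor. Compound 1 gives 1020 nM in this assay, compound 2 gives 1360 nM and compound 3 gives 820 nM; the gaps from compound 1 to either of the other two lie within the usual scatter, so the three numbers are not separated.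

The next compound, compound 4 `Cc1ccc(-c2cc(NC(=O)/C=C/c3ccc(F)cc3)n[nH]2)cc1`, has not been measured. It differs from compound 1 in one place: fluoro in place of trifluoromethyl on an aromatic carbon. Among the compounds with values here, the only measured single change is a 1.7-fold lower number from compound 2 to compound 3 (0.22 log units; within the scatter), which also concerns a substituent on an aromatic carbon para to a large group, but exchanges different groups. Within the data shown here, that step stayed within the scatter, and no measured pair involves fluoro or trifluoromethyl, so nothing here points to a step beyond the scatter in this assay in either direction.

Compound 4 is therefore expected to sit near compound 1, at 1100 nM with a range from 500 nM to 2500 nM. The expected step is a 1.1-fold higher number from compound 1 to compound 4 (0.03 log units; within the scatter).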

Compound 4, half-maximal inhibitory concentration: 1250 nM
For compound 4 the middle estimate is 1.1-fold (0.06 log units) below the measured one; the measured number falls inside the stated range.
By their numbers in this assay, from the lowest: compounds 3, 1, 4 and 2 (each within the scatter of the next).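

On an aromatic carbon of a six-membered aromatic ring of carbon only, para to a large group, fluoro in place of trifluoromethyl gives a 1.2-fold higher number from compound 1 to compound 4 (0.09 log units; within the scatter) in this assay. The substituent at this place thus goes from 4 heavy atoms to 1 heavy atom with no step beyond the scatter, and this is the second exchange para to a large group to stay within it, after the different exchange in a 1.7-fold lower number from compound 2 to compound 3 (0.22 log units; within the scatter). Nothing on hand gives a cause for this result.

On these data alone, it remains open whether an amine or a carboxylic acid at this place would give a step beyond the scatter. As far as these compounds go, it is also open whether fluoro in place of trifluoromethyl would read the same in a compound carrying bromo on the other aromatic ring.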